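Bromo to trifluoromethyl in a triazole thioether series

The source may hold more compounds than are shown below. What is called first, only, known or untested is meant among the compounds shown, and "the series" means these compounds.

Measured so far:
Compound 1, `CC(=O)Oc1ccc(/C=C/C(=O)OCCSc2nc(-c3ccc(S(C)(=O)=O)cc3)n(-c3ccc(C(F)(F)F)cc3)n2)cc1OC(C)=O`: 10200 nM
Compound 2, `CC(=O)Oc1ccc(/C=C/C(=O)NCCSc2nc(-c3ccc(S(C)(=O)=O)cc3)n(-c3ccc(F)cc3)n2)cc1OC(C)=O`: 17000 nM
Compound 3, `COc1cc(/C=C/C(=O)OCCSc2nc(-c3ccc(S(C)(=O)=O)cc3)n(-c3ccc(Br)cc3)n2)ccc1OC(C)=O`: 11100 nM

All three numbers come from a functional assay on A549 cells (Homo sapiens) for antiproliferative activity, read by MTT assay, with a stated time of 72 h; on this read-out higher numbers stand for weaker inhibition and lower numbers for stronger inhibition. Compound 3 gives the second highest of the three readings in this assay, yet every gap among them lies within the usual scatter, so none of the three can be called stronger or weaker than another. Compound 4, `COc1cc(/C=C/C(=O)OCCSc2nc(-c3ccc(S(C)(=O)=O)cc3)n(-c3ccc(C(F)(F)F)cc3)n2)ccc1OC(C)=O`, is not yet measured. It differs from compound 3 in one place: trifluoromethyl in place of bromo on an aromatic carbon. Among the compounds with values here, no measured pair isolates this exchange. Compound 1 already carries the same trifluoromethyl group and gives 10200 nM, close to compound 3. The step from compound 3 to compound 4 is therefore expected to stay within the scatter, a 1.1-fold lower number from compound 3 to compound 4 (0.02 log units; within the scatter). Compound 4 is expected at about 10500 nM, between 5000 nM and 22000 nM.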

Compound 4, half-maximal inhibitory concentration: 9650 nM
For compound 4 the middle estimate is 1.1-fold (0.04 log units) above the measured one; measured number inside the range.
By their numbers in this assay, from the lowest: compounds 4, 1, 3 and 2 (each within the scatter of the next).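

In this assay trifluoromethyl in place of bromo on this aromatic carbon, the first time this exchange is isolated, leaves the number within the scatter (a 1.2-fold lower number from compound 3 to compound 4 (0.06 log units; within the scatter)). Methyl in place of acetyl on an oxygen on an aromatic ring also stays within the scatter (a 1.1-fold lower number from compound 1 to compound 4 (0.02 log units; within the scatter)). Nothing measured here explains either result.

On these data alone, whether an amine or a carboxylic acid on that same aromatic carbon would move the number remains open. So does the effect of a longer chain in place of that methyl.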